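Thio-Sugar Nucleoside: Bromo in Place of Chloro

The source may report more compounds than this note shows. Statements on the series, on what has been measured and on what is new or still open speak of the compounds shown alone.

Compound 1, `O=c1[nH]c(=O)n([C@H]2S[C@H](CO)[C@@H](O)[C@@H]2O)cc1/C=C/Cl`, gives in a functional assay on CCRF-HSB-2 cells (Homo sapiens) for antiproliferative activity (a higher number here means a weaker inhibitor, a lower number a stronger inhibitor), the value > 100 ug/mL.
Compound 2, `O=c1[nH]c(=O)n([C@@H]2S[C@H](CO)[C@@H](O)[C@@H]2O)cc1/C=C/Cl`, gives in this assay the value > 100 ug/mL.

The value of compound 1 is a limit of this assay, not a number. The value of compound 2 is likewise only a limit. Compound 1 therefore stands at a bound, with no measured number of its own. The step that the two limits leave unreadable from compound 1 to compound 2 cannot be read, since the limit of > 100 ug/mL in this assay, at which 2 of the 2 values shown sit, together with the fact that compounds 1 and 2 differ only in the configuration as drawn leaves nothing to compare.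

Compound 3, `O=c1[nH]c(=O)n([C@H]2S[C@H](CO)[C@@H](O)[C@@H]2O)cc1/C=C/Br`, differs from compound 1 by bromo in place of chloro on a double-bonded chain carbon bound to a double-bonded chain carbon. Among the measured compounds shown here, no measured step touches this exchange; the one measured step concerns configuration alone and is itself unreadable. The expectation for compound 3 in this assay thus rests on compound 1 sitting at its limit, and the step that the limit leaves unreadable from compound 1 to compound 3 is expected to stay within the scatter. Compound 3 is estimated at 150 ug/mL, between 40 ug/mL and 600 ug/mL, and is expected most likely to be reported again only as a limit.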

Compound 3, half-maximal inhibitory concentration: > 100 ug/mL
Compound 3 gave a limit, no number; the forecaster's own chance of this, stated with the estimate: 80%; the middle value lies beyond the limit too.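

Among the compounds shown here, compound 3, like compound 1, stands only at a limit, so no step from compound 1 to compound 3 can be read in this assay: the limit of > 100 ug/mL in this assay, at which 3 of the 3 values shown sit.

The compounds shown leave open whether bromo in place of chloro alters antiproliferative activity on the shared core at all.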